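The source may hold more compounds than are shown below. What is called first, only, known or untested is meant among the compounds shown, and "the series" means these compounds.

Measured so far:
Compound 1, `CN(Cc1ccc2nccn2c1)c1nnc(-c2ccccc2)o1` — in an assay on isolated protein for inhibition of tyrosine-protein kinase receptor UFO (Homo sapiens), read by LC-MS (a higher number here means a weaker inhibitor, a lower number a stronger inhibitor), compound 1 gives > 100000 nM
Compound 2, `CN(Cc1ccc2nccn2c1)c1nnc(-c2ccc(-c3ccccc3F)cc2)o1` — in this assay compound 2 gives 1580 nM

The value for compound 1 is a limit of the assay, not a number: the limit of > 100000 nM in this assay, at which 1 of the 2 values shown sits. Compound 2 therefore stands as the only actual number shown. For the measured compounds named here, the one measured step, an at least 63-fold lower number from compound 1 to compound 2 (1.80 log units; beyond the scatter), concerns a different change: a whole 2-fluorophenyl group entering in place of hydrogen. Compound 3, `COc1ccccc1-c1ccc(-c2nnc(N(C)Cc3ccc4nccn4c3)o2)cc1`, keeps that group and alters it at a single point: methoxy in place of fluoro on an aromatic carbon. Going by the values given here, no measured step touches such a swap within the ring, so the large gain from compound 1 to compound 2 gives no direction for it, and the change is expected to shift the number only a little. For compound 3 the expected step is a 1.1-fold lower number from compound 2 to compound 3 (0.02 log units; within the scatter), not beyond the scatter. Compound 3 is thus estimated at 1500 nM, within 400 nM to 6000 nM.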

Compound 3, half-maximal inhibitory concentration: 1580 nM
The estimate for compound 3 lay 1.1-fold (0.02 log units) below the measured number; low and high end bracket the measured number.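

In this assay, methoxy in place of fluoro, ortho to a large group, gives no change at the digits printed from compound 2 to compound 3 (within the scatter), so at this position the two groups cannot be told apart, even though methoxy brings one more heavy atom and a hydrogen-bond acceptor. The large gain over hydrogen is therefore not tied to fluoro, as 2-methoxyphenyl gives an at least 63-fold lower number from compound 1 to compound 3 (1.80 log units; beyond the scatter). The size of that step is only a lower bound, as the value for compound 1 is a limit of the assay and not a number: the limit of > 100000 nM in this assay, at which 1 of the 3 values shown sits.

The compounds shown leave open whether a larger or charged group at this position, such as an amine or a carboxylic acid, would also leave the number unmoved. From the compounds shown here alone, how a plain butyl chain would compare with the 2-fluorophenyl group also stays open.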